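This account rests on a few compounds, and the source may have more. Where it says the series, first, only, none or still open, it means among the compounds named here.

Working notes on a small series of four compounds that share one core and differ in the pattern of chloro groups on it. Compound 1 is `ClCc1cccc(Cn2cnc3ncnc(Cl)c32)c1`, compound 2 is `ClCc1cccc(Cn2cnc3c(Cl)ncnc32)c1`, compound 3 is `ClCc1cccc(Cn2cnc3c(Cl)nc(Cl)nc32)c1` and the unmeasured compound 4 is `ClCc1cccc(Cn2cnc3nc(Cl)nc(Cl)c32)c1`. The cores of compound 1 and compound 2 hold the same atoms joined differently; the difference between the two cores is not broken down here.

In a functional assay on LOX IMVI cells (Homo sapiens) for cytotoxicity, read by sulforhodamine B assay, with a stated time of 48 h (a lower number here means a stronger inhibitor of growth, a higher number a weaker inhibitor of growth), compound 1 gives 14100 nM. In this assay compound 2 gives 5010 nM, and compound 3 gives 3380 nM. Compound 1 thus gives the highest number of the three measured compounds, with its gaps to compound 2 and compound 3 both beyond the scatter.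

Within the core of compound 2 the step of a 1.5-fold lower number from compound 2 to compound 3 (0.17 log units; within the scatter) goes with the change (chloro in place of hydrogen on an aromatic carbon). The same change, at a place described in the same words, turns compound 1 into compound 4: chloro in place of hydrogen on an aromatic carbon. As the place is the same word for word, the change is the same, only made on the other core.

For compound 4 in this assay the expected step is a 1.5-fold lower number from compound 1 to compound 4 (0.18 log units; within the scatter), resting on the measured step of a 1.5-fold lower number from compound 2 to compound 3 (0.17 log units; within the scatter) in compound 2, which lay within the scatter. Compound 4 is therefore estimated at 9400 nM, with a range from 4500 nM to 20000 nM expected to hold most repeat measurements.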

Compound 4, concentration for total growth inhibition: 790 nM
Beside the measured number, compound 4's estimate is 12-fold (1.08 log units) above it, and the stated range ends above it.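

In this assay, chloro in place of hydrogen on an aromatic carbon, here between two ring nitrogen atoms, gives an 18-fold lower number from compound 1 to compound 4 (1.25 log units; beyond the scatter). The size of the step did not carry over from one core to the other: the same change on two cores in this assay, a 1.5-fold lower number (0.17 log units; within the scatter) from compound 2 to compound 3 and an 18-fold lower number (1.25 log units; beyond the scatter) from compound 1 to compound 4, 12-fold (1.08 log units) apart, beyond the scatter of two such steps. In this series, then, the step on the core of compound 2 is a poor guide to the size of the step on the core of compound 1, but with a single pair on each core this shows neither why the two steps differ nor any rule for other cores or other changes.

The compounds shown have only hydrogen or chloro at this place, which leaves open whether an amine, a methyl group or a methoxy group there would also give steps that differ so much between the two cores. Going by these compounds, the part outside the core is the same in all four compounds, so it also remains open whether the gap between the two steps would persist with a different group there, such as a longer chain or a carboxylic acid.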